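This account rests on a few compounds, and the source may have more. Where it says the series, first, only, none or still open, it means among the compounds named here.

Of the compounds shown here, three built on one shared core have so far been tested in a functional assay on the whole organism for inhibition, with Rattus norvegicus as the target, at a dose of 30 mg/kg; on this read-out lower numbers stand for less inhibition and higher numbers for more inhibition at the one dose given (going by the name of the read-out). Compound 1 `CSc1ccccc1-c1nc2ncccc2o1` gives 21%. Compound 2 `COc1ccc(-c2nc3ncccc3o2)cc1` gives 14%, and compound 3 `Fc1cccc(-c2nc3cccnc3o2)c1` gives 35%. Among these three numbers compound 1 stands second highest: its gap to compound 2 lies within the usual scatter of such measurements, while compound 3 sits above it by more than that scatter. Compound 4 `Brc1ccccc1-c1nc2ncccc2o1` has not yet been measured. It differs from compound 1 by bromo in place of methylsulfanyl on an aromatic carbon. Within the data shown here, no pair of measured compounds shows a change of this kind, so only a small step in this assay is expected, and the estimated a number 4 percentage points higher from compound 1 to compound 4 (within the scatter) is thought to stay within the scatter. Compound 4 is therefore expected to give about 25%, within a range from 5% to 45%.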

Compound 4, a percentage reported as inhibition, in the whole organism at one dose (the size of the read-out at that dose, not a potency): 24%
For compound 4 the middle estimate is 1 percentage points above the measured one; low and high end bracket the measured number.
By their numbers in this assay, from the lowest: compounds 2, 1 and 4 (each within the scatter of the next); then compound 3.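

In this assay, bromo in place of methylsulfanyl on this aromatic carbon gives a number 3 percentage points higher from compound 1 to compound 4 (within the scatter), the first step read at this place on the ring. This assay therefore cannot tell these two groups apart here, although bromo has one heavy atom and methylsulfanyl has two. Nothing available explains this result. From the compounds shown here alone, whether an amine, a carboxylic acid or a longer chain such as butyl on this carbon would give a step beyond the scatter remains open. So does whether the same exchange elsewhere on this ring would behave alike.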